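The source may report more compounds than this note shows. Statements on the series, on what has been measured and on what is new or still open speak of the compounds shown alone.

Of the compounds shown here, three built on one shared core have been measured in a functional assay on ACHN cells (Homo sapiens) for cytotoxicity, read by sulforhodamine B assay, with a stated time of 72 h; a lower number here means a stronger inhibitor of growth, a higher number a weaker inhibitor of growth. Compound 1 `O=C(Nc1ccccc1C(F)(F)F)C1CCc2ccccc2N1C(=O)c1cccc(Cl)c1` gives 526 nM. Compound 2 `O=C(Nc1ccccc1C(F)(F)F)C1CCc2ccccc2N1C(=O)c1ccccc1` gives 8090 nM. Compound 3 `O=C(Nc1cc(C(F)(F)F)cc(C(F)(F)F)c1)C1CCc2ccccc2N1C(=O)c1ccccc1` gives 2920 nM. Compound 1 and compound 2 differ in a single place, (chloro in place of hydrogen on an aromatic carbon), and that change made a 15-fold lower number from compound 2 to compound 1 (1.19 log units; beyond the scatter). Compound 3 sits between the two, with compound 2 its nearer neighbour; how its core differs from that of compound 2 is not broken down here.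

Compound 4 `O=C(Nc1cc(C(F)(F)F)cc(C(F)(F)F)c1)C1CCc2ccccc2N1C(=O)c1cccc(Cl)c1` has not yet been measured. Among the compounds with values here, it differs from compound 3 by chloro in place of hydrogen on an aromatic carbon, which is the same change as the one that led from compound 2 to compound 1, at a place described in the same words. If that change carries over, the step is expected to be a 9.7-fold lower number from compound 3 to compound 4 (0.99 log units; beyond the scatter), set beside a 15-fold lower number from compound 2 to compound 1 (1.19 log units; beyond the scatter), because compound 3 starts from 2920 nM and only one earlier instance of the change is available to lean on. Compound 4 is therefore estimated at 300 nM, with a range from 100 nM to 1200 nM.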

Compound 4, concentration for 50% growth inhibition: 813 nM
Compound 4: the middle estimate sits 2.7-fold (0.43 log units) below what was measured; low and high end bracket the measured number.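

In this assay, the change from benzoyl to (3-chlorophenyl)carbonyl again gives a lower number, here a 3.6-fold lower number from compound 3 to compound 4 (0.56 log units; beyond the scatter), so on the two cores shown the direction of the change holds and a chloro group in this place helps both times. The size of the step does not hold, and the gap between the two steps is larger than repeat measurements would be expected to produce: the same change on two cores in this assay, a 15-fold lower number (1.19 log units; beyond the scatter) from compound 2 to compound 1 and a 3.6-fold lower number (0.56 log units; beyond the scatter) from compound 3 to compound 4, 4.3-fold (0.63 log units) apart, beyond the scatter of two such steps So the effect of this change depends on the rest of the molecule, but two pairs of compounds cannot say why the size differs or predict the step on a further core.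

The compounds shown leave open whether fluoro, bromo, methoxy or an amine in the same place would match chloro, and whether chloro would act the same way elsewhere on that aromatic ring. They also leave open how a carboxylic acid or a nitrile would fare in place of trifluoromethyl on either core.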